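The source may report more compounds than this note shows. Statements on the series, on what has been measured and on what is new or still open speak of the compounds shown alone.

Compound 1 `O=C(Nc1cccc(-n2cc(-c3ccncc3)c(-c3ccc(Cl)c(O)c3)n2)c1)Nc1ccc(Cl)c(Cl)c1` carries a 3,4-dichlorophenyl on an amide-type nitrogen. In a functional assay on NCI-H522 cells (Homo sapiens) for inhibition, read by sulforhodamine B assay, with a stated time of 48 h (a lower number here means that less compound is tolerated, a higher number that more compound is tolerated), compound 1 gives only a limit of the assay, > 32500 nM. Compound 2 `COc1cc(-c2nn(-c3cccc(NC(=O)c4ccc(Cl)c(C(F)(F)F)c4)c3)cc2-c2ccncc2)ccc1Cl` likewise gives only a limit, > 32500 nM. Compound 3 `COc1cc(-c2nn(-c3cccc(NC(=O)Nc4ccc(Cl)c(C(F)(F)F)c4)c3)cc2-c2ccncc2)ccc1Cl` also gives only a limit, > 32500 nM. Among the measured compounds shown here, the one step among them, a step that the two limits leave unreadable from compound 2 to compound 3, cannot be read because both ends sit at the limit of > 32500 nM in this assay, at which 3 of the 3 values shown sit. Compound 4 `O=C(Nc1cccc(-n2cc(-c3ccncc3)c(-c3ccc(Cl)c(O)c3)n2)c1)Nc1cccc(C(F)(F)F)c1` differs from compound 1 by 3-(trifluoromethyl)phenyl in place of 3,4-dichlorophenyl on an amide-type nitrogen. For the measured compounds named here, no measured step touches this exchange, so the only guide is that every value shown is a limit. The step from compound 1 to compound 4 is therefore expected to be small, a step that the limit leaves unreadable from compound 1 to compound 4, and most likely unreadable as well. Compound 4 is thus estimated at 40000 nM, with a range of 15000 nM to 100000 nM.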

Compound 4, concentration lethal to 50% of the cells: > 32500 nM
Compound 4 gave a limit, no number (the forecaster's own chance of this, stated with the estimate: 80%); the middle value does not contradict the limit.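

No step can be read from compound 1 to compound 4, since both give only a limit: the limit of > 32500 nM in this assay, at which 4 of the 4 values shown sit. The compounds shown leave open whether 3-(trifluoromethyl)phenyl in place of 3,4-dichlorophenyl changes the lethal concentration at all.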